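The compounds below may be only part of what the source reports. "The series", "measured", "known", "first", "only" and "open" are said of these compounds alone.

Of the compounds shown here, two have so far been measured in an assay on HEK293 cells for agonist activity at transient receptor potential cation channel subfamily M member 8 (Homo sapiens), read by fluorescence and calcium flux, with a stated time of 5 min; on this read-out lower numbers stand for an effect already at smaller amounts and higher numbers for an effect only at larger amounts of compound. Compound 1 `C=CCc1cc(OC)c(OC(C)C(OCCCCCCCC)c2ccc(O)c(OC)c2)c(OC)c1` gives 86 nM, the lowest of the two numbers. Compound 2 `C=CCc1cc(OC)c(O[C@H](C)[C@@H](OCC)c2ccc(O)c(OC)c2)c(OC)c1` gives 1150 nM, and the gap between compound 1 and compound 2 lies well beyond the usual scatter. The two structures differ in more than one place, so this gap cannot be assigned to any single change.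

Compound 3 `C=CCc1cc(OC)c(OC(C)C(OCCCCCCCCCC)c2ccc(O)c(OC)c2)c(OC)c1` has not yet been measured. It differs from compound 1 in one place only: ethyl in place of hydrogen on a saturated chain carbon, eight bonds along the chain from an oxygen on a saturated carbon, so the octyl chain of compound 1 becomes a decyl chain. Going by the values given here, no pair of measured compounds isolates a change of this kind, so the direction of the step has to be estimated. Compound 1, which carries the longer of the two measured chains, gives 86 nM, whereas compound 2 gives 1150 nM; a further lengthening is therefore expected to move the number little, if at all. The step from compound 1 to compound 3 is expected to be a 1.2-fold lower number from compound 1 to compound 3 (0.09 log units; within the scatter), which stays within the scatter. The estimate for compound 3 in this assay is 70 nM, with a range from 25 nM to 250 nM.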

Compound 3, half-maximal effective concentration: 66 nM
Beside the measured number, compound 3's estimate is 1.1-fold (0.03 log units) above it; low and high end bracket the measured number.
By their numbers in this assay, from the lowest: compounds 3 and 1 (each within the scatter of the next); then compound 2.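

Going by these compounds alone, this is the first pair that differ in one place only, so the effect of a single change can now be read directly. In this assay, placing ethyl on a saturated chain carbon, eight bonds along the chain from an oxygen on a saturated carbon, turns the octyl chain into a decyl chain and gives a 1.3-fold lower number from compound 1 to compound 3 (0.11 log units; within the scatter), so the two added carbons make no difference that can be told from ordinary repeat variation. Nothing at hand explains why the number holds at these two chain lengths.

The compounds shown leave open whether a still longer chain, such as dodecyl, would keep the number at this level, and how a hexyl chain would compare with the octyl chain under the same conditions. They also leave open what an amine or a carboxylic acid at the far end of the decyl chain would do to the number.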